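This account rests on a few compounds, and the source may have more. Where it says the series, first, only, none or still open, it means among the compounds named here.

Compound 1 `COc1cc(-c2nn(-c3cccc(NC(=O)Nc4cc(C(F)(F)F)cc(C(F)(F)F)c4)c3)cc2-c2ccncc2)ccc1Cl`: > 50000 nM
Compound 2 `COc1cc(-c2nn(-c3cccc(NC(=O)c4cccc(C(F)(F)F)c4)c3)cc2-c2ccncc2)ccc1Cl`: > 50000 nM

In a functional assay on ACHN cells (Homo sapiens) for inhibition, read by sulforhodamine B assay, with a stated time of 48 h (a higher number here means that more compound is tolerated, a lower number that less compound is tolerated), compound 2 gives > 50000 nM, which is a limit of the assay rather than a number. Compound 1 likewise sits at a limit, > 50000 nM. Both measured values therefore sit at the limit of > 50000 nM in this assay, at which 2 of the 2 values shown sit, so nothing measured here separates the two compounds, and the amide of compound 2 and the urea of compound 1 look alike on these numbers.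

Compound 3 `COc1cc(-c2nn(-c3cccc(NC(=O)Nc4ccc(Cl)c(C(F)(F)F)c4)c3)cc2-c2ccncc2)ccc1Cl` is not yet measured. It differs from compound 2 by (4-chloro-3-(trifluoromethyl)phenyl)amino in place of 3-(trifluoromethyl)phenyl on a carbonyl carbon, which makes it a urea like compound 1. Within the data shown here, no step between measured compounds is available to guide the change. As compound 1 with its urea also sits at the limit, the expected step that the limit leaves unreadable from compound 2 to compound 3 is none beyond the scatter, with compound 3 most likely reported as a limit again. Compound 3 is estimated at 60000 nM, within 20000 nM to 200000 nM.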

Compound 3, concentration lethal to 50% of the cells: > 32500 nM
Compound 3: no number, only a limit (the forecaster's own chance of this, stated with the estimate: 85%); the middle value does not contradict the limit.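

In this assay compound 3 gives > 32500 nM, which is a limit of the assay and not a number. Among these compounds, compound 2 also stands at a limit, so no step between compound 2 and compound 3 can be read. The compounds shown leave open whether exchanging the group on the carbonyl carbon makes any difference to the lethal concentration.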